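Tolerance in cells after one group swap on compound 3

This account rests on a few compounds, and the source may have more. Where it says the series, first, only, none or still open, it means among the compounds named here.

In an ADME assay on MT4 cells (Homo sapiens) for cytotoxicity, read by MTT assay (a lower number here means that less compound is tolerated, a higher number that more compound is tolerated), compound 1 `Cc1ccc(N(C(=O)c2cccc([N+](=O)[O-])c2)C(=S)OCCN2C(=O)c3ccccc3C2=O)cc1` gives 100000 nM, compound 2 `Cc1ccc(N(C(=O)c2cc(F)cc(F)c2)C(=S)OCCN2C(=O)c3ccccc3C2=O)cc1` gives 54000 nM and compound 3 `Cc1ccc(N(C(=O)c2c(Cl)cccc2Cl)C(=S)OCCN2C(=O)c3ccccc3C2=O)cc1` gives 22000 nM. Compound 3 therefore has the lowest number of the three, meaning that cells tolerate the least of it.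

Still unmeasured, compound 4 `Cc1ccc(N(C(=O)c2ccc(Cl)c([N+](=O)[O-])c2)C(=S)OCCN2C(=O)c3ccccc3C2=O)cc1` carries 4-chloro-3-nitrophenyl in place of 2,6-dichlorophenyl on a carbonyl carbon. All three measured steps change this same group. The step of a 4.5-fold lower number from compound 1 to compound 3 (0.66 log units; beyond the scatter) is modest, as is the step of a 2.5-fold lower number from compound 2 to compound 3 (0.39 log units; beyond the scatter), while the step of a 1.9-fold lower number from compound 1 to compound 2 (0.27 log units; within the scatter) stays within the scatter. Both steps beyond the scatter arrive at the 2,6-dichlorophenyl group and lower the number, so leaving that group should raise it. Among the compounds with values here, the nearest measured group is the 3-nitrophenyl of compound 1, at 100000 nM, but no measured compound shows what the added chloro does.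

A modest rise is expected, a 2.3-fold higher number from compound 3 to compound 4 (0.36 log units; beyond the scatter). For compound 4, the estimated value is 50000 nM, with an expected range of 20000 nM to 100000 nM.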

Compound 4, half-maximal cytotoxic concentration: 47000 nM
Estimate against measurement, compound 4: 1.1-fold (0.03 log units) above; low and high end bracket the measured number.
By their numbers in this assay, from the lowest: compound 3; then compounds 4, 2 and 1 (each within the scatter of the next, the first and the last beyond it).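

In this assay the change from 2,6-dichlorophenyl to 4-chloro-3-nitrophenyl on this carbonyl carbon gives a 2.1-fold higher number from compound 3 to compound 4 (0.33 log units; beyond the scatter) even though a chloro remains on the ring, so a chloro on this ring does not by itself hold the number down at the level of compound 3. The added chloro now has its own direct reading, with a 2.1-fold lower number from compound 1 to compound 4 (0.33 log units; beyond the scatter) for chloro in place of hydrogen on an aromatic carbon, while a 1.1-fold lower number from compound 2 to compound 4 (0.06 log units; within the scatter) leaves the 4-chloro-3-nitrophenyl and 3,5-difluorophenyl groups with no order between them. Nothing shown explains why any of these groups shifts the number.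

From the compounds shown here alone, all four compounds carry a substituted phenyl ring on this carbonyl carbon, so how a cyclohexyl or a plain methyl group would read remains open. Going by these compounds, what an amine or a carboxylic acid on that ring would do also remains open.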